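A Small Change on the Aromatic Ring

The compounds below may be only part of what the source reports. "The series", "measured", "known", "first", "only" and "open" are said of these compounds alone.

Compound 1 `C=CCNC(=O)[C@@H](NC(=O)[C@@](O)(CCCN(Cc1ccc(Br)cc1)NC(=O)[C@@H](NC(=O)OC)C(C)(C)C)Cc1ccc(CC=C)cc1)C(C)(C)C` gives > 50000 nM
Compound 2 `C=CCNC(=O)[C@@H](NC(=O)[C@@](O)(CCCN(Cc1ccc(Br)cc1)NC(=O)[C@@H](NC(=O)OC)C(C)(C)C)Cc1ccc(C=C)cc1)C(C)C` gives 25000 nM

Among the compounds with values here, in an ADME assay on MT4 cells (Homo sapiens) for cytotoxicity, read by XTT assay, with a stated time of 5 days (on this read-out higher numbers stand for lower toxicity in this test and lower numbers for higher toxicity in this test), compound 2 gives 25000 nM as the only exact number so far. Compound 1 shows > 50000 nM as a limit of the assay and not a number. Compound 3 (`C=CCNC(=O)[C@@H](NC(=O)[C@@](O)(CCCN(Cc1ccc(Br)cc1)NC(=O)[C@@H](NC(=O)OC)C(C)(C)C)Cc1ccc(CC=C)cc1)C(C)C`) differs from compound 2 by having allyl in place of vinyl on an aromatic carbon. Within the data shown here, no measured pair shows this change, so no shift beyond the usual scatter is expected in this assay in either direction. The estimated move a 1.1-fold higher number from compound 2 to compound 3 (0.05 log units; within the scatter) is therefore small. For compound 3 the expected value is 28000 nM with a range from 13000 nM to 50000 nM in this test.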

Compound 3, half-maximal cytotoxic concentration: 24000 nM
Compound 3: middle estimate off by 1.2-fold (0.07 log units), on the high side; the range from low to high includes it.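

Allyl in place of vinyl on an aromatic carbon gives a 1.0-fold lower number from compound 2 to compound 3 (0.02 log units; within the scatter) in this assay, so at this position the one extra carbon leaves no visible mark on the read-out. Hydrogen in place of methyl on the chain carbon gives an at least 2.0-fold lower number from compound 1 to compound 3 (0.31 log units; beyond the scatter), the first step here beyond the scatter. Compound 1 stands at a limit of the assay, so the full size of that step stays unknown: the limit of > 50000 nM in this assay, at which 1 of the 3 values shown sits.

Going by these compounds, whether an amine or a carboxylic acid at this aromatic position would shift the number remains open. So does whether the chain-carbon step holds on other compounds.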